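The compounds below may be only part of what the source reports. "The series", "measured", "known", "first", "only" and "open" are said of these compounds alone.

Compound 1, with the structure `O=S(=O)(CC1=NCCS1)C1C(c2ccccc2)=NN(c2ccccc2)C1c1ccccc1`, was tested in a functional assay, tested at 50 ug/mL (on this read-out higher numbers stand for a stronger effect at the one concentration tested and lower numbers for a weaker effect), and compound 1 is recorded as "not active" (no number reported), with no number behind it. A second core carries the same sulfonyl-linked side chains: compound 3, `COc1ccc(C2=NOC(c3ccc(C)cc3)C2S(=O)(=O)CC2=NCCS2)cc1`, gives 47.5% in this assay, and compound 2, `COc1ccc(C2=NOC(c3ccc(C)cc3)C2S(=O)(=O)CC2=NCCO2)cc1`, gives 65.9%. The difference between compound 2 and compound 3 is a group of 5 heavy atoms (3 carbon, 1 nitrogen, 1 oxygen; one five-membered non-aromatic ring with 2 hetero atoms) in place of a group of 5 heavy atoms (3 carbon, 1 nitrogen, 1 sulfur; one five-membered non-aromatic ring with 2 hetero atoms), on a saturated chain carbon bound to a sulfonyl sulfur, and that exchange produced a rise of a number 18.4 percentage points higher from compound 3 to compound 2 (beyond the scatter). The difference between the two cores is not broken down here.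

Compound 4, `O=S(=O)(CC1=NCCO1)C1C(c2ccccc2)=NN(c2ccccc2)C1c1ccccc1`, is not yet measured. Compound 4 differs from compound 1 by a group of 5 heavy atoms (3 carbon, 1 nitrogen, 1 oxygen; one five-membered non-aromatic ring with 2 hetero atoms) in place of a group of 5 heavy atoms (3 carbon, 1 nitrogen, 1 sulfur; one five-membered non-aromatic ring with 2 hetero atoms), on a saturated chain carbon bound to a sulfonyl sulfur, which is the same change as that from compound 3 to compound 2, at the same place. Compound 1 itself offers no number, so the earlier step can only suggest the direction; a step of roughly the size of a number 18.4 percentage points higher from compound 3 to compound 2 (beyond the scatter) applied to an inactive starting point would still leave compound 4 weak. Compound 4 is therefore expected to give about 15% in this assay, estimated within 0% to 40%.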

Compound 4, a percentage reported as activity, at one concentration (the size of the read-out at that concentration, not a potency): 44.4%
Estimate against measurement, compound 4: 29.4 percentage points below, and the stated range ends below it.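

No new step can be read from compound 1 to compound 4: in this assay compound 1 is recorded as "not active" (no number reported) without a number, so compound 4 at 44.4% has nothing to be set against. The compounds shown leave open how large this side-chain exchange is on the core of compound 1. No measured evidence bears on this result.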